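The compounds below may be only part of what the source reports. "The series", "measured", "known", "first", "only" and "open" are said of these compounds alone.

Measured so far:
- compound 1 `COc1ccc(Cl)c(-c2nnc3n2NC(c2ccc([N+](=O)[O-])o2)S3)c1`: 21.7%
- compound 2 `COc1ccc(Cl)c(-c2nnc3n2NC(c2ccc[nH]2)S3)c1`: 18.4%

Compound 1 `COc1ccc(Cl)c(-c2nnc3n2NC(c2ccc([N+](=O)[O-])o2)S3)c1` and compound 2 `COc1ccc(Cl)c(-c2nnc3n2NC(c2ccc[nH]2)S3)c1` share one core and differ only in the group attached to a saturated ring carbon. In a functional assay on the whole organism (strain Wistar Albino) for inhibition, with Rattus norvegicus as the target, read by paw edema, with a stated time of 3 h, at a dose of 20 mg/kg (on this read-out higher numbers stand for more inhibition at the one dose given (going by the name of the read-out) and lower numbers for less inhibition), compound 1 gives 21.7%, and compound 2 gives 18.4%. The step of a number 3.3 percentage points lower from compound 1 to compound 2 (within the scatter) lies within the scatter, so the two numbers cannot be told apart; compound 2 simply stands at the lower of the two numbers, with compound 1 very close to it.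

Compound 3 `COc1ccc(Cl)c(-c2nnc3n2NC(c2cccn2C)S3)c1` is not yet measured. It differs from compound 2 by methyl in place of hydrogen on an aromatic nitrogen. Within the data shown here, no measured step changes anything on that aromatic nitrogen; the only step at hand, a number 3.3 percentage points lower from compound 1 to compound 2 (within the scatter), concerns a whole group swapped on the saturated ring carbon and was within the scatter. Among the measured compounds shown here, with one small addition and no step that speaks to it, the expectation for compound 3 is no shift beyond the scatter. Compound 3 is therefore estimated at 19% (range 9% to 29%), which means an expected step of a number 0.6 percentage points higher from compound 2 to compound 3 (within the scatter).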

Compound 3, a percentage reported as inhibition, in the whole organism at one dose (the size of the read-out at that dose, not a potency): 18.5%
Beside the measured number, compound 3's estimate is 0.5 percentage points above it; low and high end bracket the measured number.
By their numbers in this assay, from the lowest: compounds 2, 3 and 1 (each within the scatter of the next).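

Methyl in place of hydrogen on an aromatic nitrogen of the five-membered aromatic ring gives, in this assay, a number 0.1 percentage points higher from compound 2 to compound 3 (within the scatter). Among these compounds, this is the first reading at that nitrogen, and it shows that the hydrogen there can be replaced by a small carbon group without any change that can be told from the scatter, even though the methyl sits next to the ring atom that bears a large group. Replacing 5-nitrofuran-2-yl with 1-methyl-1H-pyrrol-2-yl on the saturated ring carbon gives a number 3.2 percentage points lower from compound 1 to compound 3 (within the scatter), so the three groups at that carbon cannot be told apart on this read-out, and nothing else is available to explain why these changes leave the numbers so close.

Going by these compounds, whether a larger group on that nitrogen, such as an n-butyl chain or a benzyl group, or a carboxylic acid or an amine on the same ring, would move the number beyond the scatter remains open. On these data alone, it is also open whether compounds that read alike at this one dose and time would still do so at other doses or times.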